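This account rests on a few compounds, and the source may have more. Where it says the series, first, only, none or still open, it means among the compounds named here.

Compound 3 `CC(C)(C)OC(=O)NCCNC(=O)CN1CN(c2ccccc2)C2(CCN(C(=O)c3ccc(C4CCCCC4)cc3)CC2)C1=O` gives 5500 nM in an assay on HEK293 cells for displacement of a labelled ligand from NPC1-like intracellular cholesterol transporter 1 (Homo sapiens) (a higher number here means a weaker inhibitor, a lower number a stronger inhibitor), the highest of the three numbers recorded. Compound 2 `CS(=O)(=O)NCCCNC(=O)CN1CN(c2ccccc2)C2(CCN(C(=O)c3ccc(C4CCCCC4)cc3)CC2)C1=O` gives 3800 nM, a value within the scatter of compound 3, while compound 1 `CCOC(=O)C1CCN(C(=O)CN2CN(c3ccccc3)C3(CCN(C(=O)c4ccc(C5CCCCC5)cc4)CC3)C2=O)CC1` gives 900 nM, and the step of a 6.1-fold higher number from compound 1 to compound 3 (0.79 log units; beyond the scatter) lies beyond the scatter. Compound 4 `CS(=O)(=O)NCCNC(=O)CN1CN(c2ccccc2)C2(CCN(C(=O)c3ccc(C4CCCCC4)cc3)CC2)C1=O` differs from compound 3 in one place: methylsulfonyl in place of tert-butoxycarbonyl on an amine nitrogen. Among the compounds with values here, the only comparison that bears on this exchange is a 1.4-fold higher number from compound 2 to compound 3 (0.16 log units; within the scatter), which likewise sets (tert-butoxycarbonyl)amino against (methanesulfonamido)methyl, though on a chain of different length, and stays within the scatter. Within the data shown here, no measured pair isolates the exchange alone. The expected step for compound 4 is therefore a 1.2-fold lower number from compound 3 to compound 4 (0.09 log units; within the scatter), within the scatter. The estimate for compound 4 in this assay is 4500 nM, from 2000 nM to 10000 nM.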

Compound 4, half-maximal inhibitory concentration: 2100 nM
For compound 4 the middle estimate is 2.1-fold (0.33 log units) above the measured one; low and high end bracket the measured number.
By their numbers in this assay, from the lowest: compound 1; then compounds 4, 2 and 3 (each within the scatter of the next, the first and the last beyond it).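

In this assay the exchange of tert-butoxycarbonyl for methylsulfonyl on the amine nitrogen, seen here on its own, gives a 2.6-fold lower number from compound 3 to compound 4 (0.42 log units; beyond the scatter) and so registers at this position. Methanesulfonamido in place of (methanesulfonamido)methyl gives a 1.8-fold lower number from compound 2 to compound 4 (0.26 log units; within the scatter) and separates neither chain, while the 4-(ethoxycarbonyl)piperidin-1-yl amide stays ahead with a 2.3-fold higher number from compound 1 to compound 4 (0.37 log units; beyond the scatter) as its step. Nothing available explains these differences. As far as these compounds go, whether a free amine or a carboxylic acid at the end of this chain would match compound 1 remains open. So does the outcome of an acetyl or benzenesulfonyl group on the same nitrogen.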